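Bromo for chloro on the shared core: compound 3

The compounds below may be only part of what the source reports. "The series", "measured", "known", "first", "only" and "open" are said of these compounds alone.

Measured so far:
Compound 1 `O=C1NC(=O)/C(=C/c2cn(Cc3ccc(F)cc3)c3ccccc23)N1` gives 27800 nM in a functional assay on A549 cells (Homo sapiens) for antiproliferative activity, read by trypan blue exclusion, with a stated time of 24 h; on this read-out lower numbers stand for stronger inhibition and higher numbers for weaker inhibition.
Compound 2 `O=C1NC(=O)/C(=C/c2cn(Cc3ccccc3)c3ccc(Cl)cc23)N1` gives 29700 nM in this assay.

Compound 2 carries the highest of the two numbers, but compound 1 sits within the scatter of it, so the pair shows no difference worth the name. Compound 3 `O=C1NC(=O)/C(=C/c2cn(Cc3ccccc3)c3ccc(Br)cc23)N1` differs from compound 2 by bromo in place of chloro on an aromatic carbon — bromo in place of chloro on an aromatic carbon. Within the data shown here, no step between measured compounds offers a guide; in this assay the expected step is none beyond the scatter, in either direction. Compound 3 is estimated at 29000 nM, with a range from 15000 nM to 58000 nM, which amounts to an expected step of a 1.0-fold lower number from compound 2 to compound 3 (0.01 log units; within the scatter).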

Compound 3, half-maximal inhibitory concentration: > 40000 nM
Compound 3 gave a limit, no number (the forecaster's own chance of this, stated with the estimate: 5%); middle value at least 1.3-fold (0.13 log units) from the limit.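

In this assay compound 3 reads > 40000 nM, which is a limit of the assay and not a number. Bromo in place of chloro on this aromatic carbon gives an at least 1.3-fold higher number from compound 2 to compound 3 (0.12 log units; that floor lies within the scatter), so bromo here shows no sign of stronger inhibition than chloro. The step is only a floor, because it rests on a limit: the limit of > 40000 nM in this assay, at which 1 of the 3 values shown sits.

From the compounds shown here alone, whether the true step lies beyond the scatter stays open. Also open, going by these compounds, is how an amine or a carboxylic acid would read on this aromatic carbon.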